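The compounds below may be only part of what the source reports. "The series", "measured", "known", "first", "only" and "open" are said of these compounds alone.

Compound 3 `Cc1ccc(S(=O)(=O)NCc2ccc(CNC(=O)c3ccc([N+](=O)[O-])cc3)cc2)cc1` gives 10 nM in an assay on MDA-MB-231 cells for binding affinity to C-X-C chemokine receptor type 4 (Homo sapiens), read by immunofluorescence and microscopy, with stated times of 10 min and 30 min; a lower number here means that less compound is needed, a higher number that more compound is needed for the effect. On the numbers available it stands level with compound 1 `Cc1ccc(S(=O)(=O)NCc2ccc(CNC(=O)c3ccc(Cl)cc3)cc2)cc1`, which gives 10 nM, the two together the lowest of the three, whereas compound 2 `Cc1ccc(C(=O)NCc2ccc(CNS(=O)(=O)c3ccc(C)cc3)cc2)cc1` gives 1000 nM. The corresponding steps are no change at the digits printed from compound 1 to compound 3 (within the scatter) and a 100-fold lower number from compound 2 to compound 3 (2.00 log units; beyond the scatter). Compound 4 `Cc1ccc(S(=O)(=O)NCc2ccc(CNC(=O)c3cccnc3)cc2)cc1` differs from compound 3 by pyridin-3-yl in place of 4-nitrophenyl on a carbonyl carbon. Both measured steps concern the substituent on the phenyl ring attached to the carbonyl carbon, and they bear on this change only loosely: chloro and nitro give the same number, methyl a far higher one, so the exchange of the whole ring for pyridin-3-yl is not closely covered. A moderate rise is therefore expected, a 10-fold higher number from compound 3 to compound 4 (1.00 log units; beyond the scatter). Compound 4 is estimated at 100 nM, within a range from 10 nM to 1000 nM.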

Compound 4, effective concentration (reported as EC, without a stated level of effect): > 1000 nM
Compound 4: only a limit was reported (the forecaster's own chance of this, stated with the estimate: 5%); middle value at least 10-fold (1.00 log units) from the limit.
By their numbers in this assay, from the lowest: compounds 1 and 3 (each within the scatter of the next); then compound 2.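

In this assay the value of compound 4 is a limit and not a number: the limit of > 1000 nM in this assay, at which 1 of the 4 values shown sits.

The earlier compounds shown here varied only the substituent on the phenyl ring, whereas this change replaces the ring itself on the carbonyl carbon, and it gives an at least 100-fold higher number from compound 3 to compound 4 (2.00 log units; beyond the scatter) and an at least 100-fold higher number from compound 1 to compound 4 (2.00 log units; beyond the scatter). The remaining step, whose size cannot be read, is a number no lower from compound 2 to compound 4 (the limit leaves the size open).

On these data alone, it remains open whether the ring nitrogen or the loss of the chloro or nitro group matters here. As far as these compounds go, how an unsubstituted phenyl or a 4-methoxyphenyl would compare at this carbonyl carbon also remains open.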